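A few compounds are considered here, and "the series" means these few. Any claim that something is new, unique, unknown or untested is made for them only; others in the source may bear on it.

Working notes on the series. Compound 1 `COc1ccc(C2CC(c3ccccc3)=NN2C2=NC(=O)/C(=C3\C(=O)Nc4ccc(Br)cc43)S2)cc1` gives 180 nM in a functional assay on cells (Cancer cell lines, Homo sapiens) for cytotoxicity, read by sulforhodamine B assay, with a stated time of 48 h; on this read-out higher numbers stand for weaker inhibition of growth and lower numbers for stronger inhibition of growth. Compound 2 `COc1ccc(C2=NN(C3=NC(=O)/C(=C4\C(=O)Nc5ccc(Br)cc54)S3)C(c3ccc(OC)cc3)C2)cc1` gives 200 nM; the step from these two, a 1.1-fold higher number from compound 1 to compound 2 (0.05 log units; within the scatter), is a methoxy in place of hydrogen on an aromatic carbon. Compound 3 `COc1ccc(C2CC(c3ccc4ccccc4c3)=NN2C2=NC(=O)/C(=C3\C(=O)Nc4ccccc43)S2)cc1` gives 870 nM, the highest of the three numbers, beyond the scatter from both compound 2 and compound 1. Among the measured compounds shown here, compound 3 differs from compound 1 in two places at once, so its two values show only that the pair is far apart and do not separate the two changes.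

Compound 4 `COc1ccc(C2CC(c3ccc4ccccc4c3)=NN2C2=NC(=O)/C(=C3\C(=O)Nc4ccc(Br)cc43)S2)cc1` is the unmeasured member. Relative to compound 3 the change is bromo in place of hydrogen on an aromatic carbon, on an aromatic carbon of a six-membered aromatic ring of carbon only, part of a fused system of two rings, meta to a fused ring and para to a fused ring. For the measured compounds named here, no measured step is this single change. Going by the values given here, the only measured step, from compound 1 to compound 2, concerns a different group and is within the scatter. The two bromo-bearing compounds sit at the low end of the range, compound 3 without the bromo at the high end, which is the only hint available.

On that basis compound 4 is expected to give 450 nM, within 180 nM to 1100 nM, a step of a 1.9-fold lower number from compound 3 to compound 4 (0.29 log units; within the scatter) that is an estimate, not a measurement.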

Compound 4, concentration for 50% growth inhibition: 64 nM
For compound 4 the middle estimate is 7.0-fold (0.85 log units) above the measured one, and the stated range ends above it.
By their numbers in this assay, from the lowest: compound 4; then compounds 1 and 2 (each within the scatter of the next); then compound 3.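

In this assay, bromo in place of hydrogen on an aromatic carbon of the six-membered aromatic ring of carbon only, part of a fused system of two rings, meta to a fused ring and para to a fused ring, gives a 14-fold lower number from compound 3 to compound 4 (1.13 log units; beyond the scatter), so this position is now read through a single change, and that change lies beyond the scatter. With the bromo held constant, naphthalen-2-yl on the carbon with a double bond to nitrogen also gives modest steps beyond the scatter, a 2.8-fold lower number from compound 1 to compound 4 (0.45 log units; beyond the scatter) in place of phenyl and a 3.1-fold lower number from compound 2 to compound 4 (0.49 log units; beyond the scatter) in place of 4-methoxyphenyl, so the group on that carbon can shift the number, which the methoxy step alone, within the scatter, did not show. Compound 4 therefore shows the strongest inhibition of growth of the four compounds, with its steps to all the others beyond the scatter.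

From the compounds shown here alone, the bromo step is read only with naphthalen-2-yl present, so it remains open whether it carries over to the phenyl or 4-methoxyphenyl compounds, and whether chloro or an amine on the same aromatic carbon would give a step of similar size. No measurement shown here bears on why the bromo step is this large.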